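Dithiocarbamate Benzamides: Replacing the Indoline Cap

This account rests on a few compounds, and the source may have more. Where it says the series, first, only, none or still open, it means among the compounds named here.

Measured so far:
Compound 1, `Nc1ccccc1NC(=O)c1ccc(CSC(=S)N2CCc3cc(Cl)ccc32)cc1`, 82.3%
Compound 2, `Nc1ccccc1NC(=O)c1ccc(CSC(=S)N(Cc2ccccc2)Cc2ccccc2)cc1`, 32.5%

In a functional assay on A-375 cells (Homo sapiens) for antiproliferative activity, read by CCK-8 assay, with a stated time of 72 h, tested at 8 uM (a higher number here means a stronger effect of the compound at the concentration tested, a lower number a weaker effect), compound 1 gives 82.3%, the higher of the two numbers in hand. Compound 2, in this assay, gives 32.5%, a number well beyond the scatter below that of compound 1. Going by the values given here, the two compounds share the same core and differ only in the group on the thiocarbonyl carbon, so the measured numbers say that this position matters to the read-out, but no single-point step between them is set out and nothing beyond these two values is known.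

Compound 3 is `CN1CCN(C(=S)SCc2ccc(C(=O)Nc3ccccc3N)cc2)CC1`. It differs from compound 1 as follows: 4-methylpiperazin-1-yl in place of 5-chloro-2,3-dihydro-1H-indol-1-yl on a thiocarbonyl carbon. Among the compounds with values here, both prior groups on the thiocarbonyl carbon carry aromatic rings; the entering group does not, and there is no measured compound with a group of this kind. With only compound 2 as a guide to what a change at this place can do, the step from compound 1 to compound 3 in this assay is expected to be downward and beyond the scatter, a number 37.3 percentage points lower from compound 1 to compound 3 (beyond the scatter). Compound 3 is accordingly estimated at 45%, in a range from 20% to 72%.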

Compound 3, a percentage reported as inhibition, at one concentration (the size of the read-out at that concentration, not a potency): 91.6%
For compound 3 the middle estimate is 46.6 percentage points below the measured one; the whole stated range lies below it.
By their numbers in this assay, from the lowest: compound 2; then compounds 1 and 3 (each within the scatter of the next).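

In this assay, 4-methylpiperazin-1-yl in place of 5-chloro-2,3-dihydro-1H-indol-1-yl on a thiocarbonyl carbon gives a number 9.3 percentage points higher from compound 1 to compound 3 (within the scatter), so this change leaves the read-out at the level of compound 1. An aromatic ring in the group at this position is therefore not required for a high read-out, and with compound 2 at 32.5% the three compounds show that the outcome depends on which group is present, not simply on whether the indoline-derived group is replaced. No available evidence explains why compound 3 keeps this level while compound 2 does not.

On these data alone, it remains open whether the methyl group of the piperazine matters, and whether a piperazin-1-yl group with a free ring amine, a morpholin-4-yl ring or an open-chain diethylamino group on the thiocarbonyl carbon would hold the read-out at this level. With a single concentration behind each number, the values of compound 1 and compound 3 also leave their relative potency open.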